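The compounds below may be only part of what the source reports. "The series", "measured", "known", "first", "only" and "open" are said of these compounds alone.

Compound 1 `OCc1cn(Cc2cccc(Cl)c2)c2ccccc12`: 160 nM
Compound 2 `Cc1cccc(Cn2cc(CO)c3ccccc32)c1`: 1000 nM

Going by the values given here, in a functional assay on T29Kt1 cells (Homo sapiens) for cytotoxicity, read by sulforhodamine B assay, with a stated time of 3 days (on this read-out higher numbers stand for weaker inhibition and lower numbers for stronger inhibition), compound 1 gives 160 nM, the lower of the two numbers so far. Compound 3 `OCc1cn(Cc2ccc(Cl)c(Cl)c2)c2ccccc12` is the next to be read against it. The structural change is chloro in place of hydrogen on an aromatic carbon, ortho to a chloro group and para to a large group.

Among the compounds with values here, only one measured step bears on this, and only indirectly. It is a 6.3-fold higher number from compound 1 to compound 2 (0.80 log units; beyond the scatter), a modest step beyond the scatter, where methyl takes the place of chloro on an aromatic carbon. It shows that a change on this ring can move the number in this assay. However, that step removes a chloro group, whereas compound 3 keeps it and gains another. Within the data shown here, no measured compound shows the effect of adding a chloro group, so the direction remains tentative. A small move towards stronger inhibition is expected, and no change beyond the scatter would also fit. The expected step is a 1.5-fold lower number from compound 1 to compound 3 (0.16 log units; within the scatter). For compound 3 the estimated value is 110 nM, with an expected range of 40 nM to 350 nM.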

Compound 3, half-maximal inhibitory concentration: 310 nM
For compound 3 the middle estimate is 2.8-fold (0.45 log units) below the measured one; the range from low to high includes it.
By their numbers in this assay, from the lowest: compounds 1 and 3 (each within the scatter of the next); then compound 2.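

In this assay the added chloro group gives (a 1.9-fold higher number from compound 1 to compound 3 (0.29 log units; within the scatter)), so the data do not separate compound 3 from compound 1. This position, ortho to a chloro group and para to a large group, therefore accepts a second chloro group with no change that can be told from the scatter, which the earlier step could not show: it read only an exchange at the existing chloro group (a 6.3-fold higher number from compound 1 to compound 2 (0.80 log units; beyond the scatter)), not an addition to the ring. No measurement on hand accounts for either step.

Open, as far as these compounds go, is whether this tolerance belongs to the position or only to chloro, as a methoxy group, an amine or a carboxylic acid in the same place could read quite differently from compound 3. Going by these compounds alone, also open is whether a chloro group at this position would read the same on its own, with the existing chloro group replaced by hydrogen, since the one pair at hand cannot separate the contribution of each chloro group.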